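A few compounds are considered here, and "the series" means these few. Any claim that something is new, unique, unknown or untested is made for them only; others in the source may bear on it.

In a functional assay on MDA-MB-435 cells (Homo sapiens) for cytotoxicity (on this read-out lower numbers stand for stronger inhibition of growth and higher numbers for weaker inhibition of growth), compound 3 `OCCCCC#Cc1ccccc1C#Cc1cccc(O)c1` gives 16100 nM, the second highest of the three numbers measured. Compound 1 `OCCCCC#Cc1ccccc1C#Cc1ccccn1` gives 25100 nM, and a 1.6-fold lower number from compound 1 to compound 3 (0.19 log units; within the scatter). Compound 2 `COc1cccc(C#Cc2ccccc2C#CCCCCO)c1` gives 1900 nM, and an 8.5-fold higher number from compound 2 to compound 3 (0.93 log units; beyond the scatter). Compound 4 `OCCCCC#Cc1ccccc1C#Cc1cccc(C(F)(F)F)c1` carries trifluoromethyl in place of hydroxy on an aromatic carbon. The step from compound 2 to compound 3 is the closer precedent, as it too alters the group on that aromatic carbon, while the step from compound 1 to compound 3 exchanges the whole ring and offers little guidance. On that basis a lower number is expected for compound 4, roughly a 3.6-fold lower number from compound 3 to compound 4 (0.55 log units; beyond the scatter), though the size is less certain than in the precedent. The estimate for compound 4 in this assay is 4500 nM, within 1300 nM to 15000 nM.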

Compound 4, concentration for 50% growth inhibition: 16900 nM
For compound 4 the middle estimate is 3.8-fold (0.57 log units) below the measured one; the whole stated range lies below it.
By their numbers in this assay, from the lowest: compound 2; then compounds 3, 4 and 1 (each within the scatter of the next).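

In this assay, the hydroxy and trifluoromethyl groups on this aromatic carbon cannot be told apart (a 1.0-fold higher number from compound 3 to compound 4 (0.02 log units; within the scatter)), even though they differ in heavy atoms and hydrogen-bond donors and acceptors. Methoxy alone stands apart so far, with the step to trifluoromethyl (an 8.9-fold higher number from compound 2 to compound 4 (0.95 log units; beyond the scatter)) beyond the scatter, as is the step to hydroxy (an 8.5-fold higher number from compound 2 to compound 3 (0.93 log units; beyond the scatter)). Nothing available bears on why these groups group this way. Still open, going by these compounds, is whether an ethoxy group or an amine on this carbon would read like compound 2 or like compound 3 and compound 4.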